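The source may hold more compounds than are shown below. What is called first, only, known or untested is meant among the compounds shown, and "the series" means these compounds.

Three analogues share one core. Compound 1 `CN(C)c1ccc(N2C(=O)NC3(CSC4=C3C(=O)c3ncccc3C4=O)C2=O)cc1` gives 90 nM in a functional assay on ACHN cells (Homo sapiens) for antiproliferative activity, read by MTT assay, with a stated time of 96 h; on this read-out lower numbers stand for stronger inhibition and higher numbers for weaker inhibition; compound 2 `CCN(CC)c1ccc(N2C(=O)NC3(CSC4=C3C(=O)c3ncccc3C4=O)C2=O)cc1` gives 20 nM; compound 3 `CCCCCc1ccc(N2C(=O)NC3(CSC4=C3C(=O)c3ncccc3C4=O)C2=O)cc1` gives 250 nM, the highest of the three numbers. The measured steps run a 4.5-fold lower number from compound 1 to compound 2 (0.65 log units; beyond the scatter), a 2.8-fold higher number from compound 1 to compound 3 (0.44 log units; beyond the scatter) and a 13-fold higher number from compound 2 to compound 3 (1.10 log units; beyond the scatter). Compound 4 `CCCCc1ccc(N2C(=O)NC3(CSC4=C3C(=O)c3ncccc3C4=O)C2=O)cc1` differs from compound 3 by hydrogen in place of methyl on a saturated chain carbon, four bonds along the chain from an aromatic carbon. Among the compounds with values here, none of the measured steps shortens a chain by one carbon; each swaps one whole group on the aromatic carbon for another, so no step bears directly on this change. With nothing to point either way, compound 4 is expected to differ little from its parent in this assay, a step of no change at the digits printed from compound 3 to compound 4 (within the scatter), within the scatter. The estimate for compound 4 is 250 nM, with a range of 100 nM to 600 nM.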

Compound 4, half-maximal inhibitory concentration: 50 nM
Estimate against measurement, compound 4: 5.0-fold (0.70 log units) above, and the stated range ends above it.
By their numbers in this assay, from the lowest: compound 2; then compounds 4 and 1 (each within the scatter of the next); then compound 3.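

Chain length on the aromatic carbon matters in this assay: removing one methyl alone gives a 5.0-fold lower number from compound 3 to compound 4 (0.70 log units; beyond the scatter) and is the first step to show that a single carbon at this chain end changes the result. The butyl group also closes most of the gap to the amino groups, with a 1.8-fold lower number from compound 1 to compound 4 (0.26 log units; within the scatter) and no order between those two, whereas a 2.5-fold higher number from compound 2 to compound 4 (0.40 log units; beyond the scatter) leaves compound 2 with the lowest number of the four. Nothing available explains the effect of the shorter chain.

With only butyl and pentyl as chains, two points define no best length. Propyl or hexyl on the same aromatic carbon would show whether the numbers keep moving with chain length.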